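Swapping the Halogenated Aryl Group on a Weak Adenosine Binder

A few compounds are considered here, and "the series" means these few. Any claim that something is new, unique, unknown or untested is made for them only; others in the source may bear on it.

Measured compounds:
- compound 1, `Cn1c(=O)c2[nH]c(-c3ccc(S(=O)(=O)N4CCN(Cc5ccc(Cl)s5)CC4)cc3)cc2n(C)c1=O`: 5250 nM
- compound 2, `CCn1c(=O)c2[nH]c(-c3ccc(S(=O)(=O)NC4CCN(Cc5ccc(F)cc5)CC4)cc3)cc2n(CC)c1=O`: 4310 nM

Both compounds were tested in an assay on HeLa cells for displacement of a labelled ligand from adenosine receptor A3 (Homo sapiens); on this read-out lower numbers stand for stronger inhibition and higher numbers for weaker inhibition. Compound 1 gives 5250 nM, the higher of the two numbers, while compound 2 gives 4310 nM. The gap between them lies within the scatter of repeated measurements, so the two values show no real difference, and both stand for weak binding. Within the data shown here, the two compounds also differ in several places at once, so no single structural step between them can be read.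

Compound 3, `Cn1c(=O)c2[nH]c(-c3ccc(S(=O)(=O)N4CCN(Cc5ccc(Br)cc5)CC4)cc3)cc2n(C)c1=O`, is not yet measured. It differs from compound 1 in one place: 4-bromophenyl in place of 5-chlorothiophen-2-yl on a saturated chain carbon bound to an amine nitrogen in a ring. Among the measured compounds shown here, nothing among the measured compounds shows what this exchange does on its own. For the measured compounds named here, with only two weak binders to go on, and no step to lean on, the expected step of a 1.2-fold lower number from compound 1 to compound 3 (0.07 log units; within the scatter) is none beyond the scatter, in either direction. Compound 3 is therefore expected to give 4500 nM in this assay, with a range from 1500 nM to 14000 nM.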

Compound 3, half-maximal inhibitory concentration: 12300 nM
The estimate for compound 3 lay 2.7-fold (0.44 log units) below the measured number; measured number inside the range.
By their numbers in this assay, from the lowest: compounds 2 and 1 (each within the scatter of the next); then compound 3.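

In this assay, the group on a saturated chain carbon bound to an amine nitrogen in a ring does affect the number: 4-bromophenyl in place of 5-chlorothiophen-2-yl gives a 2.3-fold higher number from compound 1 to compound 3 (0.37 log units; beyond the scatter), a modest loss of binding that lies beyond the scatter. Compound 1 and compound 2 could not show this, as they differ in several places at once, whereas compound 1 and compound 3 differ only in this one group, so the step can be read for this exchange alone. Nothing measured here says why the number rises.

As far as these compounds go, this single exchange changes the ring and the halogen together, so it remains open which of the two carries the step, a question that a phenyl ring bearing chlorine or a thiophene ring bearing bromine could help to answer. From the compounds shown here alone, it also remains open whether a quite different group at this place, such as a plain phenyl ring or a phenyl ring carrying an amine or a carboxylic acid, would move the number further in either direction.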